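A few compounds are considered here, and "the series" means these few. Any claim that something is new, unique, unknown or untested is made for them only; others in the source may bear on it.

In an assay on isolated protein (strain Sprague-Dawley) for inhibition of Amine oxidase [flavin-containing] B (Rattus norvegicus), read by spectrophotometry, with a stated time of 5 min (on this read-out lower numbers stand for stronger inhibition and higher numbers for weaker inhibition), compound 1 `NC(=O)COc1cc(=O)oc2cc(OCc3cccc(Cl)c3)ccc12` gives 3.1 nM; 3.31 nM (2 entries), and its repeat readings the several entries of compound 1 in this assay, 3.1 nM; 3.31 nM (2 entries) agree closely. Compound 2 `O=c1cc(CCl)c2ccc(OCc3cccc(Cl)c3)cc2o1` gives 43.7 nM, while compound 3 `O=c1cc(CO)c2ccc(OCc3cccc(Cl)c3)cc2o1` gives 5.25 nM. Compound 3 thus holds the lower of the two single numbers, the gap being an 8.3-fold lower number from compound 2 to compound 3 (0.92 log units; beyond the scatter). Compound 4 `N#Cc1cc(=O)oc2cc(OCc3cccc(Cl)c3)ccc12` differs from compound 3 by cyano in place of hydroxymethyl on an aromatic carbon. That single measured step exchanged a group on a saturated chain carbon, not on this aromatic carbon, so it offers no direct guide. Compound 3 sits close to compound 1, which carries another group on the same aromatic carbon and gives 3.1 nM; 3.31 nM (2 entries), and this hints that this position tolerates change. No step beyond the scatter is therefore expected, a 1.1-fold higher number from compound 3 to compound 4 (0.06 log units; within the scatter). Compound 4 is estimated at 6 nM, within 1.5 nM to 25 nM.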

Compound 4, half-maximal inhibitory concentration: 102 nM
Beside the measured number, compound 4's estimate is 17-fold (1.23 log units) below it; the whole stated range lies below it.
By their numbers in this assay, from the lowest: compound 3; then compound 2; then compound 4.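

Two groups of the same size on this aromatic carbon can give very different results: cyano in place of hydroxymethyl brings a 19-fold higher number from compound 3 to compound 4 (1.29 log units; beyond the scatter), a large loss of inhibition. Cyano also falls short of chloromethyl, with a 2.3-fold higher number from compound 2 to compound 4 (0.37 log units; beyond the scatter), so this position is less forgiving than compound 1 and compound 3 suggested. Nothing shown here explains this loss.

Still open, as far as these compounds go, is how an aminomethyl group, a carboxylic acid or a longer chain ending in hydroxy would fare on this carbon. Whether any of them would match compound 3 cannot be told from these compounds.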